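Predicting Cytotoxicity After a Single Aryl Ring Exchange

A few compounds are considered here, and "the series" means these few. Any claim that something is new, unique, unknown or untested is made for them only; others in the source may bear on it.

Of the compounds shown here, three sharing a core have been tested in an ADME assay on L6 cells (Rattus norvegicus) for cytotoxicity, read by resazurin assay, with a stated time of 70 h; on this read-out lower numbers stand for stronger inhibition and higher numbers for weaker inhibition. Compound 1 `COc1cc(NC(C)CCCNC(=O)/C=C/c2ccc(Cl)cc2)c2ncccc2c1` gives 16800 nM. Compound 2 `COc1cc(NC(C)CCCNC(=O)/C=C/c2ccccc2F)c2ncccc2c1` differs from compound 1 in one place, (2-fluorophenyl in place of 4-chlorophenyl on a double-bonded chain carbon bound to a double-bonded chain carbon), and in this assay compound 2 gives 3500 nM, a step described as a 4.8-fold lower number from compound 1 to compound 2 (0.68 log units; beyond the scatter). Compound 3 `COc1cc(NC(C)CCCNC(=O)NNC(=O)/C=C/c2ccc(Cl)cc2)c2ncccc2c1` has a different core from compound 1; the difference between the two cores is not broken down here. In this assay compound 3 gives 7300 nM, the second highest of the three numbers, lying between compound 2 and compound 1 and beyond the scatter from each.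

Compound 4 `COc1cc(NC(C)CCCNC(=O)NNC(=O)/C=C/c2ccccc2F)c2ncccc2c1` has not yet been measured. It stands to compound 3 as compound 2 stands to compound 1: 2-fluorophenyl in place of 4-chlorophenyl on a double-bonded chain carbon bound to a double-bonded chain carbon. The place of the change reads the same in both pairs, so this is the same change carried out on the core of compound 3 rather than that of compound 1.

In this assay compound 4 is expected to give about 2000 nM, with a plausible range from 800 nM to 6000 nM. This expectation rests on compound 1 and compound 2, because the earlier step of a 4.8-fold lower number from compound 1 to compound 2 (0.68 log units; beyond the scatter) lowered the number well beyond the scatter. Among the measured compounds shown here, for compound 4 the expected step, a 3.7-fold lower number from compound 3 to compound 4 (0.56 log units; beyond the scatter), is set a little smaller than the earlier one, reflecting that only a single example of the change has been measured.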

Compound 4, half-maximal inhibitory concentration: 25100 nM
Estimate against measurement, compound 4: 13-fold (1.10 log units) below, and the stated range ends below it.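

In this assay the exchange of 4-chlorophenyl for 2-fluorophenyl on the core of compound 3 gives a 3.4-fold higher number from compound 3 to compound 4 (0.54 log units; beyond the scatter), so the number moves in the opposite direction to the earlier pair, and the two steps clearly differ: the same change on two cores in this assay, a 4.8-fold lower number (0.68 log units; beyond the scatter) from compound 1 to compound 2 and a 3.4-fold higher number (0.54 log units; beyond the scatter) from compound 3 to compound 4, 17-fold (1.22 log units) apart, beyond the scatter of two such steps. In this series, then, the result of this ring exchange on one core does not carry over to the other, and the step measured on the core of compound 1 did not even give the right direction on the core of compound 3. Among the compounds shown here, this does not show which part of the difference between the two cores lies behind the reversal, and with only one pair of compounds on each core, it gives no general rule for how this change behaves on other cores.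

The compounds shown leave open whether the reversal goes with the exchange of chlorine for fluorine or with the different place of the halogen on the ring. Compounds carrying 4-fluorophenyl or 2-chlorophenyl on the same double-bonded chain carbon, each made on both cores, could separate these two parts of the change.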